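A few compounds are considered here, and "the series" means these few. Any claim that something is new, unique, unknown or untested is made for them only; others in the source may bear on it.

Measured in an ADME assay for permeability, using PAMPA, with a stated time of 4 h, at pH 5.5; on this read-out higher numbers stand for higher permeability and lower numbers for lower permeability:
- compound 1 `NCCCCN(C[C@H]1Cc2ncccc2CN1)[C@H]1CCCc2cccnc21`: 17 nm/s
- compound 2 `NCCCCN(C[C@H]1Cc2cccnc2CN1)[C@H]1CCCc2cccnc21`: 2 nm/s
- compound 3 `NCCCCN(C[C@H]1Cc2nccnc2CN1)[C@H]1CCCc2cccnc21`: 2 nm/s

Compound 1 has the highest number of the three in this assay, and both compound 2 and compound 3 lie lower by more than the usual scatter. Compound 2 and compound 3 show the same value.

Next in line is compound 4 `CN(C)CCCCN(C[C@H]1Cc2ncccc2CN1)[C@H]1CCCc2cccnc21`, which keeps the core of compound 1 and changes the end of the chain: dimethylamino in place of amino on a saturated chain carbon, four bonds along the chain from an amine nitrogen. In words, dimethylamino stands in place of amino on a saturated chain carbon, four bonds along the chain from an amine nitrogen.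

Going by the values given here, no measured pair shows this change, so the expectation has no direct precedent and starts from compound 1 at 17 nm/s. A small rise is expected, possibly no larger than the scatter, and the estimate reads a 1.8-fold higher number from compound 1 to compound 4 (0.25 log units; within the scatter). For compound 4 the estimated value is 30 nm/s, with an expected range of 10 nm/s to 90 nm/s.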

Compound 4, apparent permeability: 2 nm/s
The estimate for compound 4 lay 15-fold (1.18 log units) above the measured number, and the stated range ends above it.
By their numbers in this assay, from the lowest: compounds 2, 3 and 4 (each within the scatter of the next); then compound 1.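

Notes on the chain end, read in this assay: on the core of compound 1, dimethylamino in place of amino on a saturated chain carbon, four bonds along the chain from an amine nitrogen, gives an 8.5-fold lower number from compound 1 to compound 4 (0.93 log units; beyond the scatter) in the first single-place comparison of the series. Going by these compounds alone, the end of the chain is therefore a position where this read-out responds to a change, which the earlier compounds, differing only within the core, could not show. The number of compound 1 is thus not held by its core whatever the chain end carries, and no measurement here bears on the reason for this step.

Open, on these data alone, is whether methylamino at this place stays with compound 1 or with compound 4. Also open, as far as these compounds go, is whether dimethylamino on the cores of compound 2 and compound 3 gives a step of similar size.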